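Acetylation of the ring amine in the arylamide series

The compounds below may be only part of what the source reports. "The series", "measured", "known", "first", "only" and "open" are said of these compounds alone.

Measured so far:
compound 1, `CC(=O)Nc1cccc2c(-c3cccc(NC(=O)c4cc(C(F)(F)F)cc(C(F)(F)F)c4)c3)ccnc12`: 1000 nM
compound 2, `Cc1ccc(NC(=O)c2cc(C(F)(F)F)cc(C(F)(F)F)c2)cc1-c1ccnc2c(N)cccc12`: 7400 nM

In a functional assay on A375P cells (Homo sapiens) for antiproliferative activity, read by MTT assay, with a stated time of 48 h (on this read-out higher numbers stand for weaker inhibition and lower numbers for stronger inhibition), compound 1 gives 1000 nM while compound 2 gives 7400 nM. Compound 2 thus stands at the higher of the two numbers, and the gap to compound 1 lies beyond the usual scatter. Among the measured compounds shown here, the two compounds differ in more than one place, so no single step between them is isolated: compound 1 carries an acetamido group on the core and no methyl group on the middle ring, whereas compound 2 carries a free amino group and a methyl group.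

Compound 3, `CC(=O)Nc1cccc2c(-c3cc(NC(=O)c4cc(C(F)(F)F)cc(C(F)(F)F)c4)ccc3C)ccnc12`, takes the change (acetyl in place of hydrogen on a nitrogen on an aromatic ring). It therefore combines the acetamido group seen in compound 1 with the methyl-bearing middle ring of compound 2. Given that compound 1, the only acetamido compound measured, sits at 1000 nM, a move to a lower number is expected for compound 3, of about a 3.7-fold lower number from compound 2 to compound 3 (0.57 log units; beyond the scatter), though the methyl group leaves the size uncertain. Compound 3 is estimated at 2000 nM, with a range from 700 nM to 6000 nM.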

Compound 3, half-maximal inhibitory concentration: > 20000 nM
Compound 3: a limit, no number; the forecaster's own chance of this, stated with the estimate: 5%; at least 10-fold (1.00 log units) between middle value and limit.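

In this assay the reading for compound 3 is a limit of the assay and not a number: the limit of > 20000 nM in this assay, at which 1 of the 3 values shown sits. With the methyl group held in place, acetyl in place of hydrogen on a nitrogen on an aromatic ring gives an at least 2.7-fold higher number from compound 2 to compound 3 (0.43 log units; beyond the scatter), so the change from amino to acetamido does not lower the number in this setting, something the earlier pair, which differs in more than one place, could not show. Among the compounds shown here, with the acetamido group held in place, methyl in place of hydrogen on an aromatic carbon gives an at least 20-fold higher number from compound 1 to compound 3 (1.30 log units; beyond the scatter), a large step that isolates this methyl group for the first time and shows that a single added methyl group can separate two acetamido compounds by far more than the scatter.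

The compounds shown leave open how the change from amino to acetamido reads when the methyl group is absent, as well as how far past the limit compound 3 lies. Also open, from the compounds shown here alone, is whether an ethyl group or a chlorine atom in place of the methyl, or a propionyl or methanesulfonyl group on the nitrogen, would give a step of similar size.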